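Cytotoxicity series on a shared benzothiazole-free core: amide to urea step

The compounds below may be only part of what the source reports. "The series", "measured", "known", "first", "only" and "open" are said of these compounds alone.

Of the compounds shown here, three of one shared core have been measured in a functional assay on WI-38 VA13 cells (Homo sapiens) for cytotoxicity; a higher number here means that more compound is needed for the effect, a lower number that less compound is needed. Compound 1 `O=C(Nc1ccc2nc(NC(=O)C3CCCCC3)sc2c1)c1cccc(F)c1` gives 0.64 ug/mL. Compound 2 `O=C(Nc1ccc2nc(NC(=O)C3CCCCC3)sc2c1)c1c(F)cccc1C(F)(F)F` gives 0.032 ug/mL, the lowest number of the three. Compound 3 `CCCCCCCC(=O)Nc1nc2ccc(NC(=O)c3c(Cl)cccc3Cl)cc2s1` gives 0.18 ug/mL, which places it second highest of the three numbers: its value lies between that of compound 1 above it and that of compound 2 below it, with both gaps beyond the usual scatter.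

Compound 4 `CCCCNC(=O)Nc1nc2ccc(NC(=O)c3c(Cl)cccc3Cl)cc2s1` is not yet measured. Relative to compound 3 it differs in one place: butylamino in place of heptyl on a carbonyl carbon. Cut one bond further out, the same change reads heptylcarbonyl to butylcarbamoyl, so an amide becomes a urea on the side of the core opposite the dichlorobenzoyl amide, and the chain shortens from seven carbons to four carbons with one nitrogen.

Among the compounds with values here, no measured pair in this set isolates such a change, so the expectation rests on the spread of the three numbers alone. The step is estimated as a 2.2-fold higher number from compound 3 to compound 4 (0.35 log units; beyond the scatter), a modest move toward a higher number, near the edge of the scatter. For compound 4 the expected value is 0.4 ug/mL, with a range from 0.1 ug/mL to 1.5 ug/mL.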

Compound 4, half-maximal effective concentration: 0.028 ug/mL
Estimate against measurement, compound 4: 14-fold (1.15 log units) above; measured number below the stated range.
By their numbers in this assay, from the lowest: compounds 4 and 2 (each within the scatter of the next); then compound 3; then compound 1.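

Within the data shown here, the first single-place step sits on a carbonyl carbon whose other neighbour is an amide-type nitrogen: in this assay, butylamino in place of heptyl gives a 6.4-fold lower number from compound 3 to compound 4 (0.81 log units; beyond the scatter). This position therefore moves the number, and with the dichlorobenzoyl amide held constant, the heptyl chain is not needed for a low value. Nothing available bears on the cause of this step.

The change shortens the chain and introduces the urea nitrogen together, so a pentyl amide and a heptylamino urea would be needed to separate the two contributions. Also open, going by these compounds, is whether a urea built from a cyclic amine such as piperidine, or a butyl chain ending in a carboxylic acid, would keep the value of compound 4 at 0.028 ug/mL.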